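The source may report more compounds than this note shows. Statements on the series, on what has been measured and on what is new or still open speak of the compounds shown alone.

Of the compounds shown here, two of one series have been tested in a functional assay on Hep 3B2 cells (Homo sapiens) for antiproliferative activity, read by MTT assay, with a stated time of 24 h, tested at 0.05 ug/mL; on this read-out lower numbers stand for a weaker effect and higher numbers for a stronger effect at the one concentration tested. Compound 1, with the structure `CCc1ccc2nc(C(=O)Nc3c(F)cc(-c4cccc(F)c4)cc3F)c(C)c(O)c2c1`, gives 5.62% in this assay. Compound 2, with the structure `Cc1ccc2nc(C(=O)Nc3c(F)cc(-c4cccc(F)c4)cc3F)c(C)c(C(=O)O)c2c1`, gives 2.11% in this assay. Compound 2 thus stands at the smaller of the two numbers, yet the gap to compound 1 lies within the usual scatter, so the two cannot be told apart, and they differ in more than one place, so no single change can be read from them.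

Compound 3, with the structure `CCc1ccc2nc(C(=O)Nc3c(F)cc(-c4cccc(F)c4)cc3F)c(C)c(C(=O)O)c2c1`, differs from compound 2 by a change counted as methyl in place of hydrogen on a saturated chain carbon bound to an aromatic carbon. Within the data shown here, with no measured step of this kind at hand, the step from compound 2 to compound 3 is expected to stay within the scatter, in either direction, and is estimated as a number 1.9 percentage points higher from compound 2 to compound 3 (within the scatter). Compound 3 is therefore expected to give about 4% in this assay, with a range from -5% to 15%.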

Compound 3, a percentage reported as inhibition, at one concentration (the size of the read-out at that concentration, not a potency): 0%
Estimate against measurement, compound 3: 4 percentage points above; the measured number falls inside the stated range.
By their numbers in this assay, from the lowest: compounds 3, 2 and 1 (each within the scatter of the next).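

In this assay, the change from methyl to ethyl on the saturated chain carbon bound to an aromatic carbon gives a number 2.1 percentage points lower from compound 2 to compound 3 (within the scatter), so the two compounds cannot be told apart at this position. Compound 1 and compound 3 also differ in only one place, and carboxy in place of hydroxy on an aromatic carbon gives a number 5.6 percentage points lower from compound 1 to compound 3 (within the scatter), so this swap cannot be told from the scatter either. No information is available to explain either result.

The compounds shown leave open whether a longer chain, such as propyl, on the saturated chain carbon would move the number beyond the scatter. They also leave open whether an amine or a methoxy group on the aromatic carbon that carries the hydroxy or carboxy group would do so.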